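A few compounds are considered here, and "the series" means these few. Any claim that something is new, unique, unknown or untested is made for them only; others in the source may bear on it.

In an ADME assay on THP-1 cells (Homo sapiens) for cytotoxicity, read by MTT assay, with a stated time of 72 h (on this read-out higher numbers stand for weaker inhibition and lower numbers for stronger inhibition), three compounds have been measured so far. Compound 1 `O=C(/C=C/c1ccc([N+](=O)[O-])cc1)c1c(O)c2ccccc2[nH]c1=O` gives > 50000 nM, which is a limit of the assay and not a number. Compound 2 `COc1ccc(/C=C/C(=O)c2c(O)c3ccccc3n(Cc3ccccc3)c2=O)cc1OC` gives 28700 nM, and compound 3 `Cc1ccccc1/C=C/C(=O)c1c(O)c2ccccc2n(Cc2ccccc2)c1=O` gives 45700 nM. Among the compounds with values here, compound 3 therefore has a single numerical neighbour, and the one measured step is a 1.6-fold higher number from compound 2 to compound 3 (0.20 log units; within the scatter). On these data, the two compounds cannot be told apart.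

Compound 4 `CCn1c(=O)c(C(=O)/C=C/c2ccccc2C)c(O)c2ccccc21` differs from compound 3 at one place, where benzyl becomes ethyl. Put another way, it has methyl in place of phenyl on a saturated chain carbon bound to an aromatic nitrogen. Within the data shown here, no measured step changes this place. Among the measured compounds shown here, the only measured step lies elsewhere in the molecule and stayed small, so it offers weak guidance and gives no reason to predict a large shift or a direction. Compound 1 marks (the limit of > 50000 nM in this assay, at which 1 of the 3 values shown sits), and a reading for compound 4 could likewise end at that limit.

The expected result is a 1.0-fold lower number from compound 3 to compound 4 (0.01 log units; within the scatter), meaning that no change beyond the scatter is expected. Compound 4 is estimated at 45000 nM, with an expected range from 22000 nM to 90000 nM.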

Compound 4, half-maximal inhibitory concentration: > 50000 nM
Compound 4 was reported as a limit; the forecaster's own chance of this, stated with the estimate: 45%; middle value at least 1.1-fold (0.04 log units) from the limit.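

In this assay compound 4 gives > 50000 nM, which is a limit and not a number. Within the data shown here, this is the first reading at this place, on a saturated chain carbon bound to an aromatic nitrogen, and it shows that replacing benzyl with ethyl does not bring the number into the measured range. The change can therefore be read only as a floor, an at least 1.0-fold higher number from compound 3 to compound 4 (0.03 log units; that floor lies within the scatter), and that floor does not separate the two compounds, so the true size of the step remains unknown: the limit of > 50000 nM in this assay, at which 2 of the 4 values shown sit.

Going by these compounds, it remains open whether the real value of compound 4 lies close to the limit or far from it, and therefore whether losing the phenyl ring changes cytotoxicity in these cells at all. The compounds shown also leave open how a longer chain such as propyl, an amine or a carboxylic acid would behave at this place, and whether any such group would give a number that could be compared directly with compound 3.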